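Chain Length and Aromatase Inhibition in Two Triazoles

The source may report more compounds than this note shows. Statements on the series, on what has been measured and on what is new or still open speak of the compounds shown alone.

Compound 1: `CCCCCCCCCCc1cn(C(c2ccccc2)c2ccccc2)nn1`, 13500 nM
Compound 2: `CCCCCCc1cn(Cc2ccccc2)nn1`, 7470 nM

In an assay on isolated protein for inhibition of Aromatase (Homo sapiens), read by fluorescence and colorimetric assay, with a stated time of 30 min (on this read-out higher numbers stand for weaker inhibition and lower numbers for stronger inhibition), compound 2 gives the lower of the two numbers, but its neighbour compound 1 lies within the scatter, so no order between them can be claimed. Compound 3, `CCCCCCCCCCc1cn(Cc2ccccc2)nn1`, differs from compound 2 by butyl in place of hydrogen on a saturated chain carbon, six bonds along the chain from an aromatic carbon. Among the compounds with values here, compound 2 and compound 1 differ in more than one place, so they show only two similar values. The step of a 1.3-fold higher number from compound 2 to compound 3 (0.10 log units; within the scatter) is expected to be small and within the scatter, perhaps slightly weaker. Compound 3 is estimated at 9500 nM, with a range from 3000 nM to 30000 nM.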

Compound 3, half-maximal inhibitory concentration: 6400 nM
Estimate against measurement, compound 3: 1.5-fold (0.17 log units) above; the range from low to high includes it.
By their numbers in this assay, from the lowest: compounds 3, 2 and 1 (each within the scatter of the next, the first and the last beyond it).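

In this assay the result is a 1.2-fold lower number from compound 2 to compound 3 (0.07 log units; within the scatter) for butyl in place of hydrogen on a saturated chain carbon, six bonds along the chain from an aromatic carbon, so compound 2 and compound 3 cannot be ordered. Hydrogen in place of phenyl on a saturated chain carbon bound to an aromatic carbon and an aromatic nitrogen gives a 2.1-fold lower number from compound 1 to compound 3 (0.32 log units; beyond the scatter) and is the first single change here to pass the scatter. Nothing measured here accounts for either step. On these data alone, whether an amine, a carboxylic acid or a longer chain at the chain end would shift the number remains open.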